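Compound 1 to compound 4: an isopropyl step

This account rests on a few compounds, and the source may have more. Where it says the series, first, only, none or still open, it means among the compounds named here.

In a physicochemical assay for lipophilicity (on this read-out lower numbers stand for lower lipophilicity and higher numbers for higher lipophilicity), compound 1 `OC(CC1CCCCN1)c1ccnc2ccccc12` gives 0.05, the lowest of the three numbers in hand. Compound 2 `O=C(Nc1cccc(C(F)(F)F)c1)c1cc(C(O)CC2CCCCN2)c2cccc(C(F)(F)F)c2n1` reads 2.3 and compound 3 `Cc1ccc(Oc2cc(C(O)CC3CCCCN3)c3cc(Cl)ccc3n2)cc1` reads 3.4, both beyond the scatter above compound 1. Among the measured compounds shown here, no measured pair differs in one place only, so the series offers no direct step for calibration. Compound 4 `CC(C)c1cc(C(O)CC2CCCCN2)c2ccccc2n1` is compound 1 with isopropyl in place of hydrogen on an aromatic carbon. The change sits next to the ring nitrogen. An upward step beyond the scatter is expected in this assay, estimated as a number 1.25 log units higher from compound 1 to compound 4 (beyond the scatter). For compound 4 the estimated value is 1.3, with an expected range of 0.7 to 2.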

Compound 4, partition coefficient: 1.58
For compound 4 the middle estimate is 0.28 log units below the measured one; the range from low to high includes it.
By their numbers in this assay, from the lowest: compound 1; then compound 4; then compound 2; then compound 3.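

In this assay, among the compounds shown here, isopropyl in place of hydrogen on an aromatic carbon, next to the ring nitrogen, gives a number 1.53 log units higher from compound 1 to compound 4 (beyond the scatter), the first step that can be read at one place. For the compounds shown here, this position therefore tolerates a change that moves the read-out upward, although one group gives only one step. Nothing measured here accounts for the size of that step.

Going by these compounds, whether a longer chain, an amine or a carboxylic acid at this position would move the read-out in the same direction remains open. Also open, on these data alone, is whether isopropyl gives a similar step on cores carrying other substituents.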